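The source may report more compounds than this note shows. Statements on the series, on what has been measured and on what is new or still open speak of the compounds shown alone.

Measured so far in an ADME assay on liver for metabolic stability, with Liver microsome (Homo sapiens) as the target, read by LC-MS, using microsomes; on this read-out lower numbers stand for slow clearance and higher numbers for fast clearance:

- compound 1 `CC(C)(C)C[C@@H](O)C(=O)N1N=CC[C@H]1C(=O)NCc1cc(Cl)ccc1-n1cnnn1`: 22 mL.min-1.g-1
- compound 2 `O=C(NCc1cc(Cl)ccc1-n1cnnn1)[C@@H]1CC=NN1C(=O)[C@H](O)Cc1ccccc1`: < 12 mL.min-1.g-1, a limit of the assay, not a number
- compound 3 `O=C(NCc1cc(Cl)ccc1-n1cnnn1)[C@@H]1CCNN1C(=O)[C@H](O)c1ccccc1`: < 16 mL.min-1.g-1, likewise a limit of the assay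

The change from compound 2 to compound 1 is tert-butyl in place of phenyl on a saturated chain carbon, two bonds along the chain from a carbonyl carbon and an oxygen on a saturated carbon; in this assay it gave an at least 1.8-fold higher number from compound 2 to compound 1 (0.26 log units; that floor lies within the scatter). The cores of compound 2 and compound 3 differ, and that difference is not broken down here. Compound 4 `CC(C)(C)[C@@H](O)C(=O)N1NCC[C@H]1C(=O)NCc1cc(Cl)ccc1-n1cnnn1` carries the same kind of change relative to compound 3, (tert-butyl in place of phenyl on a saturated chain carbon bound to a carbonyl carbon and an oxygen on a saturated carbon), but here the carbon is bound to the carbonyl carbon rather than two bonds along the chain from it. For compound 4 in this assay the step of an at least 1.3-fold higher number from compound 3 to compound 4 (0.13 log units; that floor lies within the scatter) is expected, resting on the earlier at least 1.8-fold higher number from compound 2 to compound 1 (0.26 log units; that floor lies within the scatter) and on the limit (the limit of < 16 mL.min-1.g-1 in this assay, at which 1 of the 3 values shown sits). Compound 4 is estimated at 22 mL.min-1.g-1, between 10 mL.min-1.g-1 and 45 mL.min-1.g-1.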

Compound 4, intrinsic clearance in microsomes: 15 mL.min-1.g-1
Compound 4: middle estimate off by 1.5-fold (0.17 log units), on the high side; the range from low to high includes it.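

In this assay the step from compound 3 to compound 4 cannot be read, since compound 3 gives only a limit of the assay: the limit of < 16 mL.min-1.g-1 in this assay, at which 1 of the 4 values shown sits.

On these data alone, whether tert-butyl in place of phenyl at this place raises or lowers the number on the core of compound 4 stays open.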